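A few compounds are considered here, and "the series" means these few. Any claim that something is new, unique, unknown or untested is made for them only; others in the source may bear on it.

In a functional assay on MGC-803 cells (Homo sapiens) for antiproliferative activity, read by MTT assay, with a stated time of 48 h (a lower number here means a stronger inhibitor, a higher number a weaker inhibitor), compound 1 (`CCCCCCCCCCn1cc(COC[C@@H]2OC[C@H](N)[C@@H]2O)nn1`) gives 8780 nM and compound 2 (`CCCCCCCCCCCCCCn1cc(COC[C@@H]2OC[C@H](N)[C@@H]2O)nn1`) gives 8210 nM. Among the measured compounds shown here, these are the only two measured values, and they lie within the scatter of each other, so compound 2 cannot be separated from compound 1. Compound 3 (`CCCCCCCCCCCCCCCCn1cc(COC[C@@H]2OC[C@H](N)[C@@H]2O)nn1`) keeps the shared core and alters only the chain: ethyl in place of hydrogen on a saturated chain carbon, ten or more bonds along the chain from an aromatic nitrogen. The change is ethyl in place of hydrogen on a saturated chain carbon, ten or more bonds along the chain from an aromatic nitrogen.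

For the measured compounds named here, one measured step bears on this change, butyl in place of hydrogen on a saturated chain carbon, and it reads a 1.1-fold lower number from compound 1 to compound 2 (0.03 log units; within the scatter), which is within the scatter. A single step is thin evidence, and the data show nothing for a chain as long as that of compound 3. Even so, no shift beyond the scatter is expected in this assay, and no direction can be favoured. The expected step is a 1.0-fold lower number from compound 2 to compound 3 (0.01 log units; within the scatter). For compound 3 the estimated value is 8000 nM, with an expected range from 3500 nM to 18000 nM.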

Compound 3, half-maximal inhibitory concentration: 27900 nM
For compound 3 the middle estimate is 3.5-fold (0.54 log units) below the measured one, and the stated range ends below it.
By their numbers in this assay, from the lowest: compounds 2 and 1 (each within the scatter of the next); then compound 3.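

The position is not indifferent to chain growth in this assay: the earlier butyl change had stayed within the scatter (a 1.1-fold lower number from compound 1 to compound 2 (0.03 log units; within the scatter)), but ethyl in place of hydrogen on a saturated chain carbon, ten or more bonds along the chain from an aromatic nitrogen, gives a step beyond it (a 3.4-fold higher number from compound 2 to compound 3 (0.53 log units; beyond the scatter)). Hexyl in place of hydrogen at the same place also gives a step beyond the scatter (a 3.2-fold higher number from compound 1 to compound 3 (0.50 log units; beyond the scatter)), so compound 3 is the weakest of the three, while compound 1 and compound 2 cannot be told apart. The response to chain growth among these three compounds is therefore not even, and no available evidence explains this turn.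

The compounds shown leave open whether a longer chain than that of compound 3 would raise the number further, and whether a chain shorter than that of compound 1 would move it at all. They also leave open how an amine or a carboxylic acid in place of hydrogen on a saturated chain carbon would read in this assay.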